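Stereochemical inversion at the ring carbon in compound 3

A few compounds are considered here, and "the series" means these few. Any claim that something is new, unique, unknown or untested is made for them only; others in the source may bear on it.

Compound 3 `CN1CCN(c2cccc3nc(CN(C)[C@H]4CCCc5cccnc54)cn23)CC1` gives 4500 nM in an ADME assay on HOS cells (Homo sapiens) for cytotoxicity; a lower number here means that less compound is tolerated, a higher number that more compound is tolerated. Compound 1 `CN(C)[C@@H]1CCN(c2cccc3nc(CN(C)[C@H]4CCCc5cccnc54)cn23)C1` gives 4900 nM, and compound 2 `CCCN(Cc1cn2c(N3CCN(C)CC3)cccc2n1)[C@H]1CCCc2cccnc21` gives 6700 nM; the steps of a 1.1-fold lower number from compound 1 to compound 3 (0.04 log units; within the scatter) and a 1.5-fold lower number from compound 2 to compound 3 (0.17 log units; within the scatter) both stay within the scatter, so compound 3 sits level with both of them on the numbers shown.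

Compound 4 `CN1CCN(c2cccc3nc(CN(C)[C@@H]4CCCc5cccnc54)cn23)CC1` differs from compound 3 only in this way: the two compounds have the same atoms and bonds and differ only in configuration as drawn: 1 of 1 stereo elements differ; a stereocentre at a saturated ring carbon is drawn S in compound 3 and R in compound 4. Among the compounds with values here, no measured step involves a change of configuration, so nothing speaks directly to this move, and the three values themselves sit within the scatter of one another. For compound 4 the expected step is a 1.1-fold higher number from compound 3 to compound 4 (0.03 log units; within the scatter), which is nothing beyond the scatter. Compound 4 is therefore estimated at 4800 nM, within 2400 nM to 9600 nM.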

Compound 4, half-maximal cytotoxic concentration: 12600 nM
Compound 4: middle estimate off by 2.6-fold (0.42 log units), on the low side, and the stated range ends below it.
By their numbers in this assay, from the lowest: compounds 3, 1, 2 and 4 (each within the scatter of the next, the first and the last beyond it).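

Inverting the saturated ring carbon from S to R gives a 2.8-fold higher number from compound 3 to compound 4 (0.45 log units; beyond the scatter) in this assay, the first single change in the series to pass the scatter. Configuration at this carbon therefore matters more here than the changes at the other two places, though the step is modest. The step can be assigned to the stereocentre alone because nothing else separates the pair: the fact that compounds 3 and 4 differ only in the configuration as drawn.

As far as these compounds go, whether the inversion carries the same step with the 3-(dimethylamino)pyrrolidin-1-yl group of compound 1 or the longer amine chain of compound 2 stays open. So does its size with a morpholin-4-yl group in place of 4-methylpiperazin-1-yl.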